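Methoxy on the pendant phenyl of compound 1

The source may report more compounds than this note shows. Statements on the series, on what has been measured and on what is new or still open speak of the compounds shown alone.

Compound 1 `N#CC1=C(N)N(c2ccc(S(N)(=O)=O)cc2)C2=C(C(=O)CCC2)C1c1ccccc1` is the parent of the set. In a functional assay on Ehrlich cells (Mus musculus) for antiproliferative activity, read by trypan blue exclusion, with a stated time of 2 h (a lower number here means a stronger inhibitor, a higher number a weaker inhibitor), compound 1 gives > 100 ug/mL, which is a limit of the assay and not a number, so compound 1 stands at the weak end of the values shown (the limit of > 100 ug/mL in this assay, at which 1 of the 2 values shown sits). Compound 2 `N#CC1=C(N)N(c2ccc(S(N)(=O)=O)cc2)C2=C(C(=O)CCC2)C1c1ccc(O)cc1` carries a hydroxy in place of hydrogen on an aromatic carbon; in this assay compound 2 gives 3 ug/mL. Among the measured compounds shown here, the step of an at least 33-fold lower number from compound 1 to compound 2 (1.52 log units; beyond the scatter) is the only measured change.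

Compound 3 `COc1ccccc1C1C(C#N)=C(N)N(c2ccc(S(N)(=O)=O)cc2)C2=C1C(=O)CCC2` is not yet measured. From compound 1 it differs by methoxy in place of hydrogen on an aromatic carbon. The measured step bears on it only loosely: the entering group is methoxy, not hydroxy, and it sits ortho to a large group. A step of an at least 3.3-fold lower number from compound 1 to compound 3 (0.52 log units; beyond the scatter) is expected, a smaller gain than that measured to compound 2. Compound 3 is therefore estimated at 30 ug/mL, within 6 ug/mL to 150 ug/mL.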

Compound 3, half-maximal inhibitory concentration: > 100 ug/mL
Compound 3: only a limit was reported (the forecaster's own chance of this, stated with the estimate: 35%); at least 3.3-fold (0.52 log units) between middle value and limit.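

In this assay compound 3 gives > 100 ug/mL, which is a limit of the assay and not a number. The step from compound 1 to compound 3 cannot be read, so methoxy ortho to a large group shows no readable gain over hydrogen, since both compounds stand at the same limit: the limit of > 100 ug/mL in this assay, at which 2 of the 3 values shown sit. Replacing 4-hydroxyphenyl with 2-methoxyphenyl on the saturated ring carbon gives an at least 33-fold higher number from compound 2 to compound 3 (1.52 log units; beyond the scatter), so among these compounds an oxygen-bearing group on the pendant phenyl is not enough to keep the activity of compound 2.

That step changes both the group and its place on the ring, and the compounds shown do not separate the two. Also open, from the compounds shown here alone, is how an amine or a carboxylic acid on the pendant phenyl would read.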